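Replacing a thiophene with a methylsulfonylphenyl group

The source may hold more compounds than are shown below. What is called first, only, known or untested is meant among the compounds shown, and "the series" means these compounds.

Measured so far:
compound 1 `CN(Cc1cccs1)C1CCN(CCCc2c[nH]c3ccc(-n4cnnc4)cc23)CC1` 140 nM
compound 2 `CN(Cc1ccsc1)C1CCN(CCCc2c[nH]c3ccc(-n4cnnc4)cc23)CC1` 35 nM

Going by the values given here, in an assay on CHO cells for displacement of a labelled ligand from 5-hydroxytryptamine receptor 1B (Homo sapiens) (a lower number here means a stronger inhibitor, a higher number a weaker inhibitor), compound 2 stands lowest of the two numbers, compound 1 being the only neighbour. Among the compounds with values here, the single measured step, a 4.0-fold lower number from compound 1 to compound 2 (0.60 log units; beyond the scatter), concerns only a swap between two thiophene isomers. Compound 3 `CN(Cc1ccc(S(C)(=O)=O)cc1)C1CCN(CCCc2c[nH]c3ccc(-n4cnnc4)cc23)CC1` carries instead (4-(methylsulfonyl)phenyl in place of thiophen-3-yl on a saturated chain carbon bound to an amine nitrogen). Within the data shown here, no measured step covers a change of this kind, so the expectation rests on the size of the group entering. For compound 3 a weakening step a 4.3-fold higher number from compound 2 to compound 3 (0.63 log units; beyond the scatter) is expected, with wide uncertainty. The estimated value for compound 3 is 150 nM, within 30 nM to 800 nM.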

Compound 3, half-maximal inhibitory concentration: 140 nM
Compound 3: the middle estimate sits 1.1-fold (0.03 log units) above what was measured, within the range that was stated.
By their numbers in this assay, from the lowest: compound 2; then compounds 1 and 3 (each within the scatter of the next).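

In this assay, the place on a saturated chain carbon bound to an amine nitrogen also accepts the larger 4-(methylsulfonyl)phenyl, a six-membered aromatic ring rather than a thiophene. Against thiophen-3-yl the number rises (a 4.0-fold higher number from compound 2 to compound 3 (0.60 log units; beyond the scatter)), while against thiophen-2-yl the result is level (no change at the digits printed from compound 1 to compound 3 (within the scatter)). No measurement shown explains either result. As far as these compounds go, it remains open how a plain phenyl group, or a phenyl group carrying a carboxylic acid, would compare here, and so whether the methylsulfonyl group itself affects the number.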